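Fluoro in place of chloro: expectations for compound 3

The source may hold more compounds than are shown below. What is called first, only, known or untested is meant among the compounds shown, and "the series" means these compounds.

Two members of the series have been measured in a functional assay on the whole organism (strain Wistar) for inhibition, with Rattus norvegicus as the target, read by paw edema, with stated times of 1 h and 5 h, at a dose of 20 mg/kg by the oral route; a higher number here means more inhibition at the dose given (going by the name of the read-out), a lower number less inhibition. Compound 1, `NS(=O)(=O)c1ccc2nc(N3N=C(c4ccc(Br)cc4)CC3c3ccc(Cl)cc3)sc2c1`, gives 14% in this assay, the lower of the two numbers available. Compound 2, `NS(=O)(=O)c1ccc2nc(N3N=C(c4ccc(Cl)cc4)CC3c3ccccc3)sc2c1`, gives 68.3%, a value that stands beyond the scatter above that of compound 1. Within the data shown here, these two differ in more than one place, so no single-point step connects them, and only the two values themselves can be set side by side.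

Compound 3, `NS(=O)(=O)c1ccc2nc(N3N=C(c4ccc(Br)cc4)CC3c3ccc(F)cc3)sc2c1`, has not yet been measured. Against compound 1 the change is fluoro in place of chloro on an aromatic carbon. Among the measured compounds shown here, the exchange is one halogen for another on an aromatic carbon of a six-membered aromatic ring of carbon only, and no measured pair isolates such an exchange, so there is nothing to calibrate it against. For compound 3 the expected step is a number 10 percentage points higher from compound 1 to compound 3 (within the scatter), small, upward if anything, and quite possibly within the scatter. Compound 3 is accordingly estimated at 24% in this assay, with a range from 8% to 48%.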

Compound 3, a percentage reported as inhibition, in the whole organism at one dose (the size of the read-out at that dose, not a potency): 14%
The estimate for compound 3 lay 10 percentage points above the measured number, within the range that was stated.
By their numbers in this assay, from the lowest: compounds 1 and 3 (each within the scatter of the next); then compound 2.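

In this assay, fluoro in place of chloro on an aromatic carbon, para to a large group, gives no change at the digits printed from compound 1 to compound 3 (within the scatter). Among these compounds, this is the first step that isolates a single place, and it gives the 4-chlorophenyl to 4-fluorophenyl exchange one measured reading: with everything else in compound 1 held fixed, the two halogens cannot be told apart at this position in this read-out, at this dose. That reading rests on one pair and applies only to the substitution pattern of compound 1, and no measurement at hand offers an explanation of why the two halogens read alike.

The compounds shown leave open whether a group of another kind at this place, such as a methoxy group, an amine or a carboxylic acid, would read apart from the two halogens. They also leave open whether fluoro in place of chloro reads the same way when the rest of the molecule differs from compound 1, as a single pair cannot show how far this result carries across the series.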